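Carbamate Chain in Place of Morpholine: Solubility Outlook

The source may report more compounds than this note shows. Statements on the series, on what has been measured and on what is new or still open speak of the compounds shown alone.

Compound 1 `Nc1nc(-c2ccccc2)nn1-c1ncnc2cc(Cl)ccc12`: 300 nM
Compound 2 `COc1cc2ncnc(-n3nc(N)nc3N)c2cc1OC`: 83000 nM
Compound 3 `COc1cc2ncnc(-n3nc(-c4ccccn4)nc3N)c2cc1OCCCN1CC(C)OC(C)C1`: 8000 nM

Of the compounds shown here, three have been measured in a physicochemical assay for solubility, in phosphate buffer, with a stated time of 18 h, at pH 7.4; on this read-out higher numbers stand for higher solubility and lower numbers for lower solubility. Among them compound 3 holds the second highest number: compound 2 sits above it and compound 1 below it, and both of those gaps lie beyond the usual scatter, so compound 3 is clearly separated from each neighbour.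

Compound 4 `CCCCCCOC(=O)NCCCOc1cc2c(-n3nc(-c4ccccn4)nc3N)ncnc2cc1OC` has not yet been measured. It differs from compound 3 in one place: (hexyloxycarbonyl)amino in place of 2,6-dimethylmorpholin-4-yl on a saturated chain carbon, three bonds along the chain from an oxygen on an aromatic ring. Within the data shown here, no measured pair in this set shares that change, so nothing here shows directly how this assay responds to it.

With the ring of compound 3 gone and a chain carrying one hydrogen-bond donor in its place, compound 4 is expected to give a somewhat lower solubility than compound 3, by a step of roughly a 3.2-fold lower number from compound 3 to compound 4 (0.51 log units; beyond the scatter), modestly beyond the scatter. On that basis compound 4 is estimated at 2500 nM, within a range of 600 nM to 9000 nM.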

Compound 4, solubility: 1000 nM
Estimate against measurement, compound 4: 2.5-fold (0.40 log units) above, within the range that was stated.
By their numbers in this assay, from the lowest: compound 1; then compound 4; then compound 3; then compound 2.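

In this assay, among these compounds, (hexyloxycarbonyl)amino in place of 2,6-dimethylmorpholin-4-yl on a saturated chain carbon, three bonds along the chain from an oxygen on an aromatic ring, gives an 8.0-fold lower number from compound 3 to compound 4 (0.90 log units; beyond the scatter), the only step in this set that reads a change at this position. Among the compounds shown here, it shows that the read-out responds to what stands at the end of this chain, which the earlier compounds, differing from each other in more than one place, could not show. No supporting measurement accompanies the step, so the data offer no account of it.

For the compounds shown here, the single step leaves the loss of the ring, the longer open chain and the added hydrogen-bond donor undivided. A simple morpholine, a piperazine, a primary amine or a shorter butyl carbamate on the same chain would be needed to tell these apart.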